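Replacing 3-hydroxyphenyl with tert-butyl in compound 2

The source may hold more compounds than are shown below. What is called first, only, known or untested is meant among the compounds shown, and "the series" means these compounds.

Among the measured compounds shown here, in a functional assay on HCT-116 cells (Homo sapiens) for antiproliferative activity, read by MTT assay, with a stated time of 72 h (on this read-out lower numbers stand for stronger inhibition and higher numbers for weaker inhibition), compound 2 (`O=C1O[C@H]([C@@H](O)Cn2cc(-c3cccc(O)c3)nn2)C(OCc2ccccc2)=C1OCc1ccccc1`) gives 42900 nM, the only actual number among the three compounds measured so far. Compound 1 (`O=C1O/C(=C\Cn2cc(-c3cc(F)cc(F)c3)nn2)C(OCc2ccccc2)=C1OCc1ccccc1`) reads > 100000 nM, which is a limit of the assay and not a number. Compound 3 (`CCCCCc1ccc(-c2cn(C/C=C3\OC(=O)C(OCc4ccccc4)=C3OCc3ccccc3)nn2)cc1`) reads > 100000 nM, which is likewise a limit. For the measured compounds named here, both differ from compound 2 in more than one place, so no direct step links them to it.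

The step followed here leads to compound 4 (`CC(C)(C)c1cn(C[C@H](O)[C@H]2OC(=O)C(OCc3ccccc3)=C2OCc2ccccc2)nn1`), with tert-butyl in place of 3-hydroxyphenyl on an aromatic carbon. Going by the values given here, the one measured change at that carbon is a step that the two limits leave unreadable from compound 1 to compound 3, so it offers no size to carry over. The expectation therefore has little to rest on beyond the spread of results in this assay. Given (the limit of > 100000 nM in this assay, at which 2 of the 3 values shown sit), a modest move toward weaker inhibition is expected rather than a gain, and the reading may turn out to be only a limit. The expected change is a 2.1-fold higher number from compound 2 to compound 4 (0.32 log units; beyond the scatter). For compound 4 the estimated value is 90000 nM, with an expected range of 35000 nM to 200000 nM.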

Compound 4, half-maximal inhibitory concentration: 28300 nM
The estimate for compound 4 lay 3.2-fold (0.50 log units) above the measured number, and the stated range ends above it.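

In this assay, putting tert-butyl in place of 3-hydroxyphenyl on the aromatic carbon of the five-membered aromatic ring with 3 nitrogen gives a 1.5-fold lower number from compound 2 to compound 4 (0.18 log units; within the scatter). Among the compounds shown here, this is the first step at this carbon with a readable size, and it places compound 2 and compound 4 within the scatter of each other, even though the entering group has no ring, no hydrogen-bond donor and fewer heavy atoms than the group it replaces. For this pair, then, neither the six-membered aromatic ring nor its hydroxyl is needed for a numerical reading, and compound 4 stays clear of the ceiling of the assay: the limit of > 100000 nM in this assay, at which 2 of the 4 values shown sit.

For the compounds shown here, the one other step at this carbon, on the core of compound 1, cannot be read, so it stays open whether tert-butyl and 3-hydroxyphenyl would also match on that core. As far as these compounds go, it also remains open how this carbon would respond to an aminomethyl group, a carboxylic acid or a longer alkyl chain in place of tert-butyl on the core of compound 4.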